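Compound 3: 2,4,6-trimethylphenyl in place of 2,6-dichlorophenyl

The compounds below may be only part of what the source reports. "The series", "measured", "known", "first", "only" and "open" are said of these compounds alone.

In a functional assay on U-87MG ATCC cells for inhibition, with U-87 MG (Homo sapiens) as the target, read by MTT assay, with a stated time of 72 h (a lower number here means a stronger inhibitor, a higher number a weaker inhibitor), compound 1 `Oc1cccc(C(Nc2ccccn2)c2ccc3cccnc3c2O)c1Cl` reads > 10000 nM, which is a limit of the assay and not a number. Among the compounds with values here, compound 2 `Oc1c(C(Nc2ccccn2)c2c(Cl)cccc2Cl)ccc2cccnc12` reads 6900 nM, the only actual number so far.

Compound 3 `Cc1cc(C)c(C(Nc2ccccn2)c2ccc3cccnc3c2O)c(C)c1` keeps the shared core and differs from compound 2 in a single place, with 2,4,6-trimethylphenyl in place of 2,6-dichlorophenyl on a saturated chain carbon bound to an aromatic carbon and a nitrogen on an aromatic ring.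

Within the data shown here, only one measured step bears on this change. It falls at the same place but brings in the 2,6-dichlorophenyl group from a different starting group, and it amounts to an at least 1.4-fold lower number from compound 1 to compound 2 (0.16 log units; that floor lies within the scatter). It rests on (the limit of > 10000 nM in this assay, at which 1 of the 2 values shown sits), so it gives a floor and no true size. Nothing measured yet shows how 2,4,6-trimethylphenyl behaves.

Among the measured compounds shown here, with only the step to compound 2 as a guide, no direction can be assigned, and no shift beyond the scatter is expected in this assay. The expected step is a 1.1-fold lower number from compound 2 to compound 3 (0.03 log units; within the scatter). For compound 3 the estimate is 6500 nM, with an expected range of 2500 nM to 14000 nM.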

Compound 3, half-maximal inhibitory concentration: 10000 nM
Compound 3: middle estimate off by 1.5-fold (0.19 log units), on the low side; the measured number falls inside the stated range.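

In this assay, the change on a saturated chain carbon bound to an aromatic carbon and a nitrogen on an aromatic ring now has a step with a real number at both ends: a 1.4-fold higher number from compound 2 to compound 3 (0.16 log units; within the scatter). On this evidence, 2,6-dichlorophenyl and 2,4,6-trimethylphenyl cannot be told apart at this position, so for this pair an aromatic ring of carbon with methyl groups serves as well as one with chlorine in this read-out. Compound 1 stands at a limit, and the step that starts from it gives no size: a number no higher from compound 1 to compound 3 (the limit leaves the size open). So 2-chloro-3-hydroxyphenyl cannot be ranked against 2,4,6-trimethylphenyl: the limit of > 10000 nM in this assay, at which 1 of the 3 values shown sits.

No step shown at this position lies beyond the scatter, so it remains open whether any group here can shift the number clearly. On these data alone, a carboxylic acid or an amine on the phenyl ring, or a longer chain in place of 2,4,6-trimethylphenyl, would test this, and the effect of changes elsewhere on the shared core also remains open.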